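Replacing 4-nitrophenyl with 3,4-dihydroxyphenyl on a carbonyl carbon

This account rests on a few compounds, and the source may have more. Where it says the series, first, only, none or still open, it means among the compounds named here.

Measured so far in an ADME assay on MDCK cells (Canis lupus familiaris) for cytotoxicity, read by MTT assay, with a stated time of 48 h (a lower number here means that less compound is tolerated, a higher number that more compound is tolerated), are two compounds:
Compound 1 `COc1ccc(C(=O)Nc2nc3nc(-c4ccccc4)cc(C)n3n2)cc1` gives > 250000 nM (a limit)
Compound 2 `Cc1cc(-c2ccccc2)nc2nc(NC(=O)c3ccc([N+](=O)[O-])cc3)nn12` gives > 250000 nM (a limit)

For compound 2 the result of > 250000 nM is a limit of this assay and not a number. Its standing among the measured compounds is therefore simple: the record shows the limit of > 250000 nM in this assay, at which 2 of the 2 values shown sit, and nothing finer.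

The account now turns to compound 3 `Cc1cc(-c2ccccc2)nc2nc(NC(=O)c3ccc(O)c(O)c3)nn12`, which has 3,4-dihydroxyphenyl in place of 4-nitrophenyl on a carbonyl carbon, and the change counts as 3,4-dihydroxyphenyl in place of 4-nitrophenyl on a carbonyl carbon in full.

For the measured compounds named here, one measured step bears on this, and it touches the same aromatic group: a step that the two limits leave unreadable from compound 1 to compound 2 gives neither a size nor a direction. It therefore offers no measured guide to how a change of this group moves the result, and the expectation rests on the shared limit alone. The expected outcome is an at least 1.2-fold lower number from compound 2 to compound 3 (0.09 log units; that floor lies within the scatter) with no clear shift beyond the scatter, and a further limit is quite possible. For compound 3 the estimated value is 200000 nM with 80000 nM to 250000 nM as its expected range.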

Compound 3, half-maximal cytotoxic concentration: 112000 nM
Compound 3: middle estimate off by 1.8-fold (0.25 log units), on the high side; the range from low to high includes it.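

The earlier pair showed nothing about this position, since the step between its two compounds cannot be read. With 3,4-dihydroxyphenyl on the carbonyl carbon, the result in this assay moves: the change from 4-nitrophenyl gives an at least 2.2-fold lower number from compound 2 to compound 3 (0.34 log units; beyond the scatter), and the change from 4-methoxyphenyl gives an at least 2.2-fold lower number from compound 1 to compound 3 (0.34 log units; beyond the scatter). Both sizes are floors and not exact sizes, so the group on this carbonyl carbon can shift the result, and compound 3 alone of the three gives a number rather than a limit, while the other two stay at the limit: the limit of > 250000 nM in this assay, at which 2 of the 3 values shown sit.

The compounds shown leave open how much larger these steps really are, and whether both hydroxyl groups of the 3,4-dihydroxyphenyl group are needed for the shift or a phenyl ring with a single hydroxyl group would give it too. They also leave open how an amine or a carboxylic acid on the phenyl ring at this same place would read, so the shift cannot yet be tied to hydroxyl groups in particular.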